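Butylamino in place of cyclopropylamino: expected cytotoxicity

The source may report more compounds than this note shows. Statements on the series, on what has been measured and on what is new or still open speak of the compounds shown alone.

Measured compounds:
compound 1, `CCOc1nc(N)nc2c1ncn2/C=C1/CC1(CO)CO`: in an ADME assay on BCBL1 cells (Homo sapiens) for cytotoxicity, with a stated time of 7 days (on this read-out lower numbers stand for higher toxicity in this test and higher numbers for lower toxicity in this test), compound 1 gives > 20000 nM, which is a limit of the assay.
compound 2, `Nc1nc(NC2CC2)c2ncn(/C=C3/CC3(CO)CO)c2n1`: in this assay compound 2 gives 71500 nM.

Compound 2 thus holds the only number shown in this assay; the other value is a limit. The step that the limit leaves unreadable from compound 1 to compound 2 cannot be read in size, because the limit of > 20000 nM in this assay, at which 1 of the 2 values shown sits, hides its starting point.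

Compound 3, `CCCCNc1nc(N)nc2c1ncn2/C=C1/CC1(CO)CO`, differs from compound 2 by butyl in place of cyclopropyl on a nitrogen on an aromatic ring. Going by the values given here, none of the measured steps touches this nitrogen, and the single measured step is itself unreadable, so the data give no direction for the new change. Compound 3 is therefore expected to sit close to compound 2, with a step of a 1.2-fold lower number from compound 2 to compound 3 (0.08 log units; within the scatter) that stays within the usual scatter. The estimate for compound 3 in this assay is 60000 nM, with a range from 20000 nM to 200000 nM.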

Compound 3, half-maximal cytotoxic concentration: > 20000 nM
Compound 3: only a limit was reported; the forecaster's own chance of this, stated with the estimate: 30%; the middle value is on the limit's open side.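

In this assay compound 3 gives > 20000 nM as a limit. Going by these compounds alone, no step from compound 1 or compound 2 to compound 3 can be read in size, because of this: the limit of > 20000 nM in this assay, at which 2 of the 3 values shown sit. The compounds shown leave open whether butyl and cyclopropyl on the nitrogen differ in this assay at all.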